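The source may report more compounds than this note shows. Statements on the series, on what has been measured and on what is new or still open speak of the compounds shown alone.

Of the compounds shown here, three share one core and have been tested in a functional assay for agonist activity at P2Y purinoceptor 2 (Homo sapiens), read by FLIPR; on this read-out lower numbers stand for an effect already at smaller amounts and higher numbers for an effect only at larger amounts of compound. Compound 1 `O=c1c2ccc(F)cc2ccn1[C@@H]1O[C@H](COP(=O)(O)OP(=O)(O)OP(=O)(O)O)[C@@H](O)[C@H]1O` gives 77 nM in this assay, compound 2 `CS(=O)(=O)c1ccc2ccn([C@@H]3O[C@H](COP(=O)(O)OP(=O)(O)OP(=O)(O)O)[C@@H](O)[C@H]3O)c(=O)c2c1` gives 650 nM, and compound 3 `O=c1c2cc(F)c(F)cc2ccn1[C@@H]1O[C@H](COP(=O)(O)OP(=O)(O)OP(=O)(O)O)[C@@H](O)[C@H]1O` gives 16 nM. Compound 3 therefore has the lowest number of the three, with its nearest neighbour being compound 1 and its most distant being compound 2. For the measured compounds named here, the only single-point change among them is a 4.8-fold lower number from compound 1 to compound 3 (0.68 log units; beyond the scatter), so adding a second fluoro to the ring brought a clear gain. Going by the values given here, no single step links compound 2 to the others; its value simply stands well above both.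

Compound 4 `CN(C)c1cc2ccn([C@@H]3O[C@H](COP(=O)(O)OP(=O)(O)OP(=O)(O)O)[C@@H](O)[C@H]3O)c(=O)c2cc1F` differs from compound 3 by dimethylamino in place of fluoro on an aromatic carbon. Among the compounds with values here, no measured step involves a dimethylamino group or an exchange of fluoro for a group of three heavy atoms, so the one step seen, a 4.8-fold lower number from compound 1 to compound 3 (0.68 log units; beyond the scatter), bears on the new step only loosely: it shows that this part of the core is sensitive to what sits there. Compound 2, carrying a group of several heavy atoms and a hydrogen-bond acceptor at the ring, gives a high number, and by that comparison compound 4 is expected to show a 5.6-fold higher number from compound 3 to compound 4 (0.75 log units; beyond the scatter). The estimate for compound 4 in this assay is 90 nM, with a likely range from 20 nM to 400 nM.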

Compound 4, half-maximal effective concentration: 4 nM
Beside the measured number, compound 4's estimate is 23-fold (1.35 log units) above it, outside the stated range (below it).
By their numbers in this assay, from the lowest: compound 4; then compound 3; then compound 1; then compound 2.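

In this assay, putting dimethylamino in place of fluoro on this aromatic carbon gives a 4.0-fold lower number from compound 3 to compound 4 (0.60 log units; beyond the scatter). So this carbon, which already carries fluoro in compound 1, is not restricted to a single heavy atom: a group of three heavy atoms, including a nitrogen that counts as a hydrogen-bond acceptor, is accepted here and the number still falls. For the compounds shown here, the earlier step, a 4.8-fold lower number from compound 1 to compound 3 (0.68 log units; beyond the scatter), added a fluoro to a different ring carbon, so only this new step shows what a change on this carbon does, and nothing available explains why the exchange lowers the number.

The compounds shown leave open whether the low number of compound 4 depends on the fluoro group ortho to the dimethylamino, since that fluoro stays in place in both compound 3 and compound 4. They also leave open how far this carbon tolerates other groups, such as a plain amino group, methoxy, diethylamino or a ring amine such as pyrrolidine, and whether any of these would move the number further in the same direction.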